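Swapping the benzyl group on a sulfonamide-amine chain

A few compounds are considered here, and "the series" means these few. Any claim that something is new, unique, unknown or untested is made for them only; others in the source may bear on it.

Measured so far:
compound 1 `O=S(=O)(NCCCNCc1ccccc1Cl)c1cc(C(F)(F)F)cc(C(F)(F)F)c1`: 11000 nM
compound 2 `CC(C)c1ccc(S(=O)(=O)NCCCCCCNCc2ccc(Br)cc2)cc1`: 5730 nM

In a functional assay on MIA PaCa-2 cells (Homo sapiens) for inhibition, read by MTT assay, with a stated time of 72 h (on this read-out higher numbers stand for weaker inhibition of growth and lower numbers for stronger inhibition of growth), compound 1 gives 11000 nM. Compound 2, built on a different sulfonyl group and a longer chain, gives 5730 nM, and the two numbers lie within the usual scatter of each other, so no order between them can be read. Compound 3 `COc1ccc(CNCCCNS(=O)(=O)c2cc(C(F)(F)F)cc(C(F)(F)F)c2)cc1` differs from compound 1 by one change: 4-methoxyphenyl in place of 2-chlorophenyl on a saturated chain carbon bound to an amine nitrogen. For the measured compounds named here, no measured pair shows this change, so the expected step from compound 1 to compound 3 is a 1.1-fold higher number from compound 1 to compound 3 (0.04 log units; within the scatter), none beyond the scatter. Compound 3 is therefore estimated at 12000 nM, within 4000 nM to 36000 nM.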

Compound 3, concentration for 50% growth inhibition: 2500 nM
Estimate against measurement, compound 3: 4.8-fold (0.68 log units) above; measured number outside the range, below it.
By their numbers in this assay, from the lowest: compound 3; then compounds 2 and 1 (each within the scatter of the next).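

In this assay, 4-methoxyphenyl in place of 2-chlorophenyl on a saturated chain carbon bound to an amine nitrogen gives a 4.4-fold lower number from compound 1 to compound 3 (0.64 log units; beyond the scatter) and so shows that growth inhibition at this place responds to the aryl group it carries. Nothing at hand explains this step. On these data alone, the change alters both the substituent and where it sits, so whether the methoxy group or its location matters stays open; 4-chlorophenyl or 2-methoxyphenyl would separate the two. As far as these compounds go, whether the same change holds on the core of compound 2 also remains open.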